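Notes on the triazole phenol series: removing the tosyl group

This account rests on a few compounds, and the source may have more. Where it says the series, first, only, none or still open, it means among the compounds named here.

Measured so far:
Compound 1 `Cc1c(O)ccc2c1[C@H](Cn1cc(-c3ccccc3)nn1)[C@@]13CC(=O)[C@@](C)(CC[C@@H]21)C3` — in a functional assay on HL-60 cells (Homo sapiens) for cytotoxicity, read by MTT assay, with a stated time of 4 days (on this read-out higher numbers stand for weaker inhibition and lower numbers for stronger inhibition), compound 1 gives > 20000 nM, which is a limit of the assay.
Compound 2 `Cc1c(O)ccc2c1[C@H](Cn1cc(-c3ccc(F)cc3)nn1)[C@@]13CC(=O)[C@@](C)(CC[C@@H]21)C3` — in this assay compound 2 gives > 20000 nM, again a limit.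
Compound 3 `COc1ccc(-c2cn(C[C@H]3c4c(ccc(OS(=O)(=O)c5ccc(C)cc5)c4C)[C@@H]4CC[C@@]5(C)C[C@]43CC5=O)nn2)cc1` — in this assay compound 3 gives > 20000 nM, also a limit.

Compound 3 therefore stands where every other measured compound stands: at the limit of > 20000 nM in this assay, at which 3 of the 3 values shown sit. No number is known for any of the three, only the limit. For the measured compounds named here, the single one-point step so far, a step that the two limits leave unreadable from compound 1 to compound 2, is unreadable because both ends are limits, so it says nothing about how a change at the aromatic ring on the triazole moves the read-out.

The next compound, compound 4 `COc1ccc(-c2cn(C[C@H]3c4c(ccc(O)c4C)[C@@H]4CC[C@@]5(C)C[C@]43CC5=O)nn2)cc1`, differs from compound 3 by hydrogen in place of (4-methylphenyl)sulfonyl on an oxygen on an aromatic ring. Going by the values given here, compounds 1 and 2 already carry the free hydroxy on the same core and sit at the limit, so there is no measured step that bears directly on this change and none that reads at all.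

With every value at the limit, the expected step that the limit leaves unreadable from compound 3 to compound 4 is none beyond the scatter, and the most likely outcome is another limit. Compound 4 is estimated at 25000 nM in this assay, with a range from 8000 nM to 80000 nM.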

Compound 4, half-maximal inhibitory concentration: > 20000 nM
Compound 4: only a limit was reported; the forecaster's own chance of this, stated with the estimate: 85%; the middle value lies beyond the limit too.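

In this assay compound 4 gives > 20000 nM, which is a limit of the assay. The steps joining compound 1, compound 2 and compound 3 to compound 4 therefore cannot be read, and all four compounds share one position: the limit of > 20000 nM in this assay, at which 4 of the 4 values shown sit.

The compounds shown leave open whether any of these changes moves the read-out at all.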